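A few compounds are considered here, and "the series" means these few. Any claim that something is new, unique, unknown or untested is made for them only; others in the source may bear on it.

Measured in a functional assay on NCI-H1975 cells (Homo sapiens) for cytotoxicity, read by MTT assay, with a stated time of 72 h (on this read-out lower numbers stand for stronger inhibition and higher numbers for weaker inhibition), so far:
- Compound 1 `CC(C)n1c(Nc2ccccc2)nc2cnc(Nc3ccc(N4CCN(C)CC4)cc3)nc21` (960 nM)
- Compound 2 `CC(=O)Nc1ccc(Nc2ncc3nc(Nc4ccccc4)n(C4CCCC4)c3n2)cc1` (1210 nM)
- Compound 3 `CN1CCN(c2ccc(Nc3ncc4nc(Nc5cccc([N+](=O)[O-])c5)n(C5CCCC5)c4n3)cc2)CC1` (980 nM)

Compound 3 stands level with both neighbours: its value lies within the scatter of compound 1 and of compound 2, so no order can be read among the three. These compounds differ from one another in more than one place, so no single change has a measured effect in this assay yet. In particular, nothing yet shows what replacing the 3-nitrophenyl group does on its own.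

The next compound is compound 4 `CN1CCN(c2ccc(Nc3ncc4nc(Nc5cc(Cl)ccc5Cl)n(C5CCCC5)c4n3)cc2)CC1`, which differs from compound 3 at one place only. It carries 2,5-dichlorophenyl in place of 3-nitrophenyl on a nitrogen on an aromatic ring. The other parts of compound 3 are kept.

Among the compounds with values here, with no measured precedent for this change, the expectation rests on the close agreement of the three values, with compound 3 itself at 980 nM as the starting point. No step beyond the scatter is expected, and no firm direction can be argued. The expected step of a 1.2-fold lower number from compound 3 to compound 4 (0.09 log units; within the scatter) is therefore small. From the compounds shown here alone, the range is kept wide since the change itself is untested. Compound 4 is estimated at 800 nM (expected range 300 nM to 2100 nM).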

Compound 4, half-maximal inhibitory concentration: 2540 nM
Beside the measured number, compound 4's estimate is 3.2-fold (0.50 log units) below it, and the stated range ends below it.
By their numbers in this assay, from the lowest: compounds 1, 3 and 2 (each within the scatter of the next); then compound 4.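

In this assay, within the data shown here, the change gives a 2.6-fold higher number from compound 3 to compound 4 (0.41 log units; beyond the scatter) as a modest step beyond the scatter, the first single change with a measured effect. Among these compounds, the read-out therefore responds to what sits on a nitrogen on an aromatic ring, and in this exchange of 3-nitrophenyl for 2,5-dichlorophenyl it moves toward weaker inhibition, an effect the level values of the earlier compounds could not reveal. Nothing at hand explains why the number moves with this change.

The step replaces a nitro group with two chlorine atoms in one move, so it cannot show whether the loss of the nitro group, the arrival of the chlorines or their placement accounts for the shift. Also open, from the compounds shown here alone, is how the series would read in this assay with an amine or a carboxylic acid on the phenyl ring, or with a pyridine ring in place of that phenyl ring, while the rest of compound 3 is kept.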